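From acetyl to iodo: the step to compound 4

This account rests on a few compounds, and the source may have more. Where it says the series, first, only, none or still open, it means among the compounds named here.

In an ADME assay on HEK293 cells (Homo sapiens) for cytotoxicity, read by MTT assay, with a stated time of 48 h (on this read-out lower numbers stand for stronger inhibition and higher numbers for weaker inhibition), compound 1 `C=C1CCC[C@]2(C)CCC(C=O)=CC[C@@]12C` gives 734000 nM, compound 2 `C=C1CCC[C@]2(C)CCC(c3cn(-c4ccc(OC)cc4)nn3)=CC[C@@]12C` gives 410000 nM and compound 3 `C=C1CCC[C@]2(C)CCC(c3cn(-c4ccc(C(C)=O)cc4)nn3)=CC[C@@]12C` gives 520000 nM. Compound 3 thus lies within the scatter of both compound 1 and compound 2, so its number offers no clear separation from either.

The next compound, compound 4 `C=C1CCC[C@]2(C)CCC(c3cn(-c4ccc(I)cc4)nn3)=CC[C@@]12C`, keeps the shared core and carries iodo in place of acetyl on an aromatic carbon, para to a large group: iodo in place of acetyl on an aromatic carbon. In words of the whole substituent, 4-acetylphenyl becomes 4-iodophenyl.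

Among the compounds with values here, one measured step bears on this change. Acetyl in place of methoxy on an aromatic carbon gave a 1.3-fold higher number from compound 2 to compound 3 (0.10 log units; within the scatter), which stays within the scatter. Within the data shown here, no measured compound carries iodo, so that group has no direct precedent in this set, and the single step is thin evidence.

With compound 3 at 520000 nM as the starting point, no shift beyond the scatter is expected in this assay. The expected move, a 1.2-fold lower number from compound 3 to compound 4 (0.08 log units; within the scatter), is estimated to remain within the scatter, with no firm direction. For compound 4 the estimate is 430000 nM, with an expected range from 210000 nM to 800000 nM.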

Compound 4, half-maximal inhibitory concentration: 215000 nM
Beside the measured number, compound 4's estimate is 2.0-fold (0.30 log units) above it; low and high end bracket the measured number.
By their numbers in this assay, from the lowest: compounds 4, 2, 3 and 1 (each within the scatter of the next, the first and the last beyond it).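

At the aromatic carbon para to a large group, in this assay, iodo in place of acetyl gives a 2.4-fold lower number from compound 3 to compound 4 (0.38 log units; beyond the scatter) and is the only step at this position shown so far that lies beyond the scatter, though only modestly. Iodo in place of methoxy gives a 1.9-fold lower number from compound 2 to compound 4 (0.28 log units; within the scatter) and stays within the scatter, so compound 4 separates from compound 3 but not from compound 2, and the size of the effect at this position depends on which pair is read. No measured data here account for the step from acetyl to iodo.

From the compounds shown here alone, with only three substituents compared at this carbon, it remains open whether the separation follows from the arrival of iodo or the departure of acetyl, and whether bromo, chloro, an amine or a carboxylic acid in the same place would give numbers that differ from those of compound 3 and compound 4. Going by these compounds, it also remains open whether the step between compound 3 and compound 4 would hold in any cell line or read-out other than this assay as used here.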